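Three limits and a shorter hydroxyalkyl chain on the urea

A few compounds are considered here, and "the series" means these few. Any claim that something is new, unique, unknown or untested is made for them only; others in the source may bear on it.

Compound 1 `COc1cc(NC(C)CCCNC(=O)NNC(=O)NCCCCCO)c2ncccc2c1` gives > 100000 nM in a functional assay on NCI-H460 cells (Homo sapiens) for inhibition, read by MTT assay, with a stated time of 4 days (a higher number here means a weaker inhibitor, a lower number a stronger inhibitor), which is a limit of the assay and not a number.
Compound 2 `COc1cc(NC(C)CCCNC(=O)NN)c2ncccc2c1` gives > 100000 nM in this assay, again a limit.
Compound 3 `COc1cc(NC(C)CCCNC(=O)NNC(=O)NC(CO)(CO)CO)c2ncccc2c1` gives > 100000 nM in this assay, also a limit.

All three measured compounds sit at the limit of > 100000 nM in this assay, at which 3 of the 3 values shown sit, so none of the steps among them can be read: the step that the two limits leave unreadable from compound 1 to compound 2, the step that the two limits leave unreadable from compound 1 to compound 3 and the step that the two limits leave unreadable from compound 2 to compound 3 each fall between two limits. Compound 3 therefore stands nowhere in particular on these numbers; it shares a limit with the other two.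

Compound 4 `COc1cc(NC(C)CCCNC(=O)NNC(=O)NCCCO)c2ncccc2c1` is the next compound. It differs from compound 3 only on the amide-type nitrogen of the terminal urea: 3-hydroxypropyl in place of 2-hydroxy-1,1-bis(hydroxymethyl)ethyl on an amide-type nitrogen. The measured steps that bear on this change are those that vary the same terminal group, from compound 1 to compound 3 and from compound 2 to compound 3, and both were left unreadable by the limits. Going by the values given here, there is no measured step of known size to carry over. The expected step of a number no higher from compound 3 to compound 4 (the limit leaves the size open) is therefore none beyond the scatter, and most probably another limit. Compound 4 is expected to give about 100000 nM in this assay, with a range from 40000 nM to 300000 nM.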

Compound 4, half-maximal inhibitory concentration: > 100000 nM
Compound 4 gave a limit, no number; the forecaster's own chance of this, stated with the estimate: 85%; the middle value lies on the limit itself.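

In this assay compound 4 gives > 100000 nM, which is a limit and not a number. Its steps to compound 1, compound 2 and compound 3 therefore cannot be read, and all four compounds share one limit: the limit of > 100000 nM in this assay, at which 4 of the 4 values shown sit.

The compounds shown leave open how strongly any of them inhibits, and whether the group on the terminal urea makes any difference.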